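From 4-fluorophenyl to pyridin-4-yl on a shared core

A few compounds are considered here, and "the series" means these few. Any claim that something is new, unique, unknown or untested is made for them only; others in the source may bear on it.

In a functional assay on MCF7 cells (Homo sapiens) for cytotoxicity, read by WST assay, with a stated time of 72 h (a lower number here means a stronger inhibitor, a higher number a weaker inhibitor), compound 1 (`O=C1Nc2c(ccc(F)c2F)C1(c1ccc(O)cc1)c1ccc(F)cc1`) gives 2.6 nM, the lowest of the two numbers available, and compound 3 (`COc1ccc(C2(c3cccc(O)c3)C(=O)Nc3c2ccc(F)c3F)cc1`) gives 196 nM. Compound 2 (`CCCCCOc1ccc(C2(c3ccc(O)cc3)C(=O)Nc3c2ccc(F)c3F)cc1`) reads > 1000 nM, which is a limit of the assay and not a number. Compound 4 (`O=C1Nc2c(ccc(F)c2F)C1(c1ccncc1)c1ccc(O)cc1`) has not yet been measured. It carries pyridin-4-yl in place of 4-fluorophenyl on a saturated ring carbon. Going by the values given here, only one measured step touches that same group, replacing its fluoro with pentyloxy: an at least 380-fold higher number from compound 1 to compound 2 (2.58 log units; beyond the scatter). This step is large, and its size rests on (the limit of > 1000 nM in this assay, at which 1 of the 3 values shown sits). The group that enters compound 4 is quite different from pentyloxy, so this step gives a direction rather than a size. A moderate rise in the number is therefore expected, and the estimated change is a 9.6-fold higher number from compound 1 to compound 4 (0.98 log units; beyond the scatter). For compound 4, the expected value is 25 nM, with an estimated range from 5 nM to 200 nM.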

Compound 4, half-maximal inhibitory concentration: 37 nM
The estimate for compound 4 lay 1.5-fold (0.17 log units) below the measured number, within the range that was stated.
By their numbers in this assay, from the lowest: compound 1; then compound 4; then compound 3. At a limit, above all of these: compound 2.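

In this assay, this position now has its first step that ends on a number at both sides: a 14-fold higher number from compound 1 to compound 4 (1.15 log units; beyond the scatter). For compound 2, the earlier step at this group ended at a limit and gave only a direction: the limit of > 1000 nM in this assay, at which 1 of the 4 values shown sits. Compound 4 adds that exchanging the whole ring on the saturated ring carbon, with a ring nitrogen entering and the fluorine leaving, raises the number by a large step, yet still gives a measured value.

The compounds shown do not separate the entry of the ring nitrogen from the loss of the fluorine. From the compounds shown here alone, whether a plain phenyl, a pyridin-3-yl or a phenyl carrying an amine on this carbon would read closer to compound 1 also stays open.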